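Selenium for sulfur on the imine carbon of compound 2

The source may hold more compounds than are shown below. What is called first, only, known or untested is meant among the compounds shown, and "the series" means these compounds.

Of the compounds shown here, two have been measured in a functional assay on PC-3 cells (Homo sapiens) for cytotoxicity, read by MTT assay, with a stated time of 72 h; on this read-out higher numbers stand for weaker inhibition of growth and lower numbers for stronger inhibition of growth. Compound 1 `CS/C(=N\C(=O)c1ccno1)NC(=O)c1ccno1` gives 99200 nM. Compound 2 `CS/C(=N\C(=O)c1csc([N+](=O)[O-])c1)NC(=O)c1csc([N+](=O)[O-])c1` gives 41500 nM, the lower of the two numbers; the gap between compound 1 and compound 2 lies beyond the usual scatter, so compound 2 is the stronger inhibitor of growth of the pair. Compound 3 `C[Se]/C(=N\C(=O)c1csc([N+](=O)[O-])c1)NC(=O)c1csc([N+](=O)[O-])c1` has not yet been measured in this assay. It differs from compound 2 in one place: a group of 2 heavy atoms (1 carbon, 1 selenium; no ring) in place of a group of 2 heavy atoms (1 carbon, 1 sulfur; no ring), on a carbon with a double bond to nitrogen. The two nitro-substituted thiophene amide arms of compound 2 are kept unchanged.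

Within the data shown here, no measured pair in this set changes a sulfur-bearing group for a selenium-bearing one, so nothing on hand tells how large such a step is. Compound 3 is expected to fall close to compound 2, with a step of a 1.4-fold lower number from compound 2 to compound 3 (0.14 log units; within the scatter) that may lie within the scatter or be a modest lowering. The estimate for compound 3 is 30000 nM, with a range from 10000 nM to 90000 nM.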

Compound 3, concentration for 50% growth inhibition: 100 nM
Compound 3: middle estimate off by 300-fold (2.48 log units), on the high side; measured number outside the range, below it.
By their numbers in this assay, from the lowest: compound 3; then compound 2; then compound 1.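

In this assay, the group on the carbon with a double bond to nitrogen proves decisive for this series: replacing methylsulfanyl with the corresponding methyl group on selenium gives a 420-fold lower number from compound 2 to compound 3 (2.62 log units; beyond the scatter) while the rest of the structure stays the same. Compound 1 and compound 2 both carry methylsulfanyl at this place, so they gave no sign that a one-atom exchange here could alter growth inhibition so strongly. Nothing available accounts for the size of this step or shows how the selenium-bearing compound acts on these cells.

The compounds shown leave open whether the same exchange would have a comparable effect with the amide arms of compound 1, as the selenium-bearing group is seen here only with those of compound 2. They also leave open whether the large step depends on selenium alone or on selenium together with its methyl group, a question that an ethyl group on selenium, or an amine on the same carbon in its place, would help to address.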